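The source may report more compounds than this note shows. Statements on the series, on what has been measured and on what is new or still open speak of the compounds shown alone.

Values in a functional assay on the whole organism for antagonist activity, with Mus musculus as the target (a higher number here means that more compound is needed for the effect, a lower number that less compound is needed), for the series:
- compound 1 `CCNC1CCCC1N(C(=O)CC)c1ccc(Cl)c(Cl)c1` gives 2 mg/kg
- compound 2 `C=CCNC1CCCC1N(C(=O)CC)c1ccc(Cl)c(Cl)c1` gives 3 mg/kg
- compound 3 `CCC(=O)N(c1ccc(Cl)c(Cl)c1)C1CCCC1N(CC)CC` gives 0.03 mg/kg

Compound 3 has the lowest number of the three, beyond the scatter from both others. Compound 4 `C=CCN(C)C1CCCC1N(C(=O)CC)c1ccc(Cl)c(Cl)c1` carries allyl(methyl)amino in place of diethylamino on a saturated ring carbon and has not been measured yet.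

Two large steps lead to compound 3: a 67-fold lower number from compound 1 to compound 3 (1.82 log units; beyond the scatter) and a 100-fold lower number from compound 2 to compound 3 (2.00 log units; beyond the scatter). The allyl-for-ethyl comparison on the secondary amines stayed within the scatter: a 1.5-fold higher number from compound 1 to compound 2 (0.18 log units; within the scatter). Like compound 3, compound 4 has no hydrogen on the amine nitrogen, so it is expected to stay close to compound 3 rather than to compounds 1 and 2. The expected step in this assay is modest, towards a higher number, and is estimated as a 2.7-fold higher number from compound 3 to compound 4 (0.43 log units; beyond the scatter) here. The estimate for compound 4 is 0.08 mg/kg (0.02 mg/kg to 0.4 mg/kg).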

Compound 4, dose for half-maximal effect: 0.2 mg/kg
Beside the measured number, compound 4's estimate is 2.5-fold (0.40 log units) below it, within the range that was stated.
By their numbers in this assay, from the lowest: compound 3; then compound 4; then compounds 1 and 2 (each within the scatter of the next).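

In this assay, a second substituent on the amine nitrogen accounts for much of the gap to the secondary amines, with a 15-fold lower number from compound 2 to compound 4 (1.18 log units; beyond the scatter) and a 10-fold lower number from compound 1 to compound 4 (1.00 log units; beyond the scatter). Losing the hydrogen on that nitrogen is not enough to match diethylamino, however (a 6.7-fold higher number from compound 3 to compound 4 (0.82 log units; beyond the scatter)), so the identity of the two substituents also matters at this saturated ring carbon. No measured evidence explains this difference.

As far as these compounds go, it remains open whether the allyl or the methyl drives the rise from diethylamino. Allyl(ethyl)amino and ethyl(methyl)amino would separate the two, while dimethylamino would test a smaller pair.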